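Methyl on the imidazole ring, across two cores

A few compounds are considered here, and "the series" means these few. Any claim that something is new, unique, unknown or untested is made for them only; others in the source may bear on it.

Compound 1 `CC1CCC(=O)N1CC#CCn1ccnc1` is the reference. In a functional assay on the whole organism for antagonist activity, with Mus musculus as the target (a lower number here means that less compound is needed, a higher number that more compound is needed for the effect), compound 1 gives 0.54 mg/kg. Compound 2 `Cc1cncn1CC#CCN1C(=O)CCC1C` differs from it by one change, (methyl in place of hydrogen on an aromatic carbon), and in this assay compound 2 gives 0.8 mg/kg. The step of a 1.5-fold higher number from compound 1 to compound 2 (0.17 log units; within the scatter).

Compound 3 `O=C1OCCN1CC#CCn1ccnc1` carries a different core; the difference between the two cores is not broken down here. In this assay compound 3 reaches only a limit, > 100 mg/kg, and so no number is known for it. That this value is a limit is recorded as the limit of > 100 mg/kg in this assay, at which 1 of the 3 values shown sits.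

Compound 4 `Cc1cncn1CC#CCN1CCOC1=O` has not yet been measured. It stands to compound 3 as compound 2 stands to compound 1, the change being (methyl in place of hydrogen on an aromatic carbon), the same change in the same place. The step that the limit leaves unreadable from compound 3 to compound 4 is expected to be small, because the same change produced a 1.5-fold higher number from compound 1 to compound 2 (0.17 log units; within the scatter). Since compound 3 shows only a limit, compound 4 is expected to show a limit as well, with an estimate of 150 mg/kg between 30 mg/kg and 1000 mg/kg.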

Compound 4, dose for half-maximal effect: 37 mg/kg
Compound 4: middle estimate off by 4.1-fold (0.61 log units), on the high side; low and high end bracket the measured number.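

In this assay, methyl in place of hydrogen on an aromatic carbon gives an at least 2.7-fold lower number from compound 3 to compound 4 (0.43 log units; beyond the scatter), so in this series the change does not carry over from the core of compound 1 to the core of compound 3 with the same outcome: the same change on two cores in this assay, a 1.5-fold higher number (0.17 log units; within the scatter) from compound 1 to compound 2 and an at least 2.7-fold lower number (0.43 log units; beyond the scatter) from compound 3 to compound 4, at least 4.0-fold (0.60 log units) apart, beyond the scatter of two such steps. On these data alone, the value of compound 3 is a limit and not a number, so the true size of the new step stays unknown and only its lower bound can be read: the limit of > 100 mg/kg in this assay, at which 1 of the 4 values shown sits. The two pairs show that the outcome of this change depended on the core here, but they do not show why, and two pairs give no rule for any other core.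

The compounds shown leave open whether an ethyl group or a chlorine atom in the same place would behave as methyl does on these two cores. They also leave open whether the same methyl change on a third core would follow either pair.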